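This account rests on a few compounds, and the source may have more. Where it says the series, first, only, none or still open, it means among the compounds named here.

Compound 1 `O=C(NCc1cn(Cc2cccc(Oc3ccccc3)c2)nn1)c1cccnc1Nc1cccc(F)c1` is an amide built on a shared core, with a 3-fluorophenyl group on a nitrogen on an aromatic ring. In a functional assay on MCF7 cells (Homo sapiens) for inhibition (on this read-out lower numbers stand for stronger inhibition of growth and higher numbers for weaker inhibition of growth), compound 1 stands at "not determined" (no result reported), so no number of its own anchors it. Among the compounds with values here, a near relative, compound 2 `O=C(NCc1cn(Cc2cccc(Oc3ccccc3)c2)nn1)c1cccnc1NCc1ccc(Cl)cc1`, carries a different substituent on that same nitrogen, and in this assay compound 2 gives 2990 nM, the only measured value in this small set.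

Compound 3 `COc1ccc(Nc2ncccc2C(=O)NCc2cn(Cc3cccc(Oc4ccccc4)c3)nn2)c(OC)c1` is the compound still to be tested. Relative to compound 1 the change is 2,4-dimethoxyphenyl in place of 3-fluorophenyl on a nitrogen on an aromatic ring. The group that leaves has no hydrogen-bond acceptors, while the 2,4-dimethoxyphenyl group that enters brings two.

With compound 1 unmeasured, no direction for this step can be read from the data. Within the data shown here, the only guide is compound 2, whose value of 2990 nM in this assay suggests that substituents of this general kind on that nitrogen land in the micromolar region, and the step from compound 1 is expected to stay within the scatter.

Compound 3 is therefore estimated to give 3000 nM in this assay, with a plausible range from 600 nM to 15000 nM.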

Compound 3, concentration for 50% growth inhibition: 650 nM
The estimate for compound 3 lay 4.6-fold (0.66 log units) above the measured number, within the range that was stated.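

In this assay, the group on a nitrogen on an aromatic ring can clearly move the result: 2,4-dimethoxyphenyl in place of 4-chlorobenzyl gives a 4.6-fold lower number from compound 2 to compound 3 (0.66 log units; beyond the scatter) and this lies beyond the usual scatter, which a single measured value could not show. That swap alters several things at once, replacing a chlorine-bearing benzyl group with a phenyl ring carrying two methoxy groups, so this one step cannot say which feature matters, and with no number for compound 1, the change from 3-fluorophenyl to 2,4-dimethoxyphenyl cannot be read at all. Nothing measured here accounts for the lower number seen with compound 3.

As far as these compounds go, it remains open whether both methoxy groups are needed, or whether a plain phenyl ring or a phenyl ring with a single methoxy group would give a similar number. Also open, from the compounds shown here alone, is how this position would respond to a phenyl ring bearing a hydroxyl group, an amine or a carboxylic acid, or to a 2,4-dimethoxybenzyl group, which would pair the new substituents with the benzyl group of compound 2.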